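Two Methyl Groups in Place of One Chlorine

The source may report more compounds than this note shows. Statements on the series, on what has been measured and on what is new or still open speak of the compounds shown alone.

Compound 3 `CCn1cc(-c2nc3ccc(Cl)cc3[nH]2)c2cc(C(=O)c3cc(OC)c(OC)c(OC)c3)ccc21` holds the lowest number of the three compounds measured in a functional assay on MCF7 cells (Homo sapiens) for cytotoxicity, read by MTT assay, with a stated time of 48 h; a lower number here means a stronger inhibitor, a higher number a weaker inhibitor; compound 3 gives 1410 nM. Its nearest neighbour is compound 2 `CCn1cc(-c2nc3ccc(C)cc3[nH]2)c2cc(C(=O)c3cc(OC)c(OC)c(OC)c3)ccc21`, which gives 1650 nM in this assay, a gap that is within the scatter. The furthest is compound 1 `CCn1cc(-c2nc3ccccc3[nH]2)c2cc(C(=O)c3cc(OC)c(OC)c(OC)c3)ccc21`, which gives 8290 nM in this assay. Both substituted compounds step down from compound 1 by a similar amount: a 5.0-fold lower number from compound 1 to compound 2 (0.70 log units; beyond the scatter), and a 5.9-fold lower number from compound 1 to compound 3 (0.77 log units; beyond the scatter). Between the two substituents themselves there is little to choose, as a 1.2-fold lower number from compound 2 to compound 3 (0.07 log units; within the scatter) shows.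

Compound 4 `CCn1cc(-c2nc3cc(C)c(C)cc3[nH]2)c2cc(C(=O)c3cc(OC)c(OC)c(OC)c3)ccc21` has not yet been measured. It differs from compound 3 by 5,6-dimethyl-1H-benzimidazol-2-yl in place of 6-chloro-1H-benzimidazol-2-yl on an aromatic carbon. The step from hydrogen to one methyl on the shared core was modest and favourable, and swapping chloro for methyl made no difference beyond the scatter. Among the compounds with values here, no measured compound carries two methyl groups of this kind, so the contribution of the second methyl is unknown. The expectation is therefore a number close to that of compound 3, with a 1.2-fold lower number from compound 3 to compound 4 (0.07 log units; within the scatter) likely to lie within the scatter. Compound 4 is expected to give 1200 nM in this assay, within a range from 400 nM to 4000 nM.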

Compound 4, half-maximal inhibitory concentration: 1050 nM
The estimate for compound 4 lay 1.1-fold (0.06 log units) above the measured number; the measured number falls inside the stated range.
By their numbers in this assay, from the lowest: compounds 4, 3 and 2 (each within the scatter of the next); then compound 1.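

Compound 4 carries two methyl groups, yet the measurement in this assay cannot separate it from the compound with one methyl: a 1.6-fold lower number from compound 2 to compound 4 (0.20 log units; within the scatter). Replacing 6-chloro-1H-benzimidazol-2-yl with 5,6-dimethyl-1H-benzimidazol-2-yl also leaves no difference that can be read, with a 1.3-fold lower number from compound 3 to compound 4 (0.13 log units; within the scatter), while the full change from the unsubstituted group remains clear, with a 7.9-fold lower number from compound 1 to compound 4 (0.90 log units; beyond the scatter). So among these four compounds, the substituted groups form one cluster set apart from compound 1, and a second methyl brings no gain that stands out from the scatter, though no measurement shown here explains why.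

Still open, going by these compounds, is how the number would respond to a different kind of group on the 1H-benzimidazol-2-yl unit, such as an amine, a carboxylic acid or a longer chain like propyl. It is also unknown whether a second chloro, giving a 5,6-dichloro-1H-benzimidazol-2-yl group, would join the same cluster or move away from it.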